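This account rests on a few compounds, and the source may have more. Where it says the series, first, only, none or still open, it means among the compounds named here.

Measured compounds:
- compound 1, `COc1ccc(C[C@@H](O)/C=C/C=C/C(=O)N2CCN(c3ccccc3)CC2)cc1OC`: 12000 nM
- compound 2, `COc1ccc(C[C@@H](O)/C=C/C=C/C(=O)N2CCN(C(c3ccccc3)c3ccccc3)CC2)cc1OC`: 12500 nM
- compound 3, `COc1ccc(C[C@@H](O)/C=C/C=C/C(=O)NCc2cc(OC)c(OC)c(OC)c2)cc1OC`: 15300 nM

Going by the values given here, in a functional assay on MCF7 cells (Homo sapiens) for antiproliferative activity, read by sulforhodamine B assay, with a stated time of 48 h (a lower number here means a stronger inhibitor, a higher number a weaker inhibitor), compound 1 gives 12000 nM, which is the lowest of the three numbers measured so far. Compound 2 gives 12500 nM and compound 3 gives 15300 nM, and both of these lie within the usual scatter of the number for compound 1, so none of the three can be set apart from the others. All three compounds share the same core and differ only in the group attached to the amide.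

Compound 4, `COc1ccc(C[C@@H](O)/C=C/C=C/C(=O)N2CCN(C)CC2)cc1OC`, has not yet been measured in this assay. It differs from compound 1 in one place: methyl in place of phenyl on an amine nitrogen in a ring. Among the compounds with values here, no step between two measured compounds matches this change, so there is nothing to set its size from. The three measured compounds, with quite different groups at the amide end, all give numbers that sit close together, which suggests the step from compound 1 to compound 4 is expected to stay small, probably none beyond the scatter, with a slight lean toward a weaker inhibitor: a 1.3-fold higher number from compound 1 to compound 4 (0.12 log units; within the scatter). Compound 4 is therefore estimated to give 16000 nM, within a range of 6000 nM to 45000 nM.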

Compound 4, half-maximal inhibitory concentration: 17100 nM
Compound 4: the middle estimate sits 1.1-fold (0.03 log units) below what was measured; low and high end bracket the measured number.
By their numbers in this assay, from the lowest: compounds 1, 2, 3 and 4 (each within the scatter of the next).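

Putting methyl in place of phenyl on an amine nitrogen in a ring removes a whole six-membered aromatic ring, yet in this assay the change gives a 1.4-fold higher number from compound 1 to compound 4 (0.15 log units; within the scatter). Going by these compounds alone, this is the first direct reading at this position: in this assay, the phenyl ring of compound 1 is not needed to keep the number where it stands, and a group as small as methyl cannot be told apart from it. Nothing measured here explains why this position tolerates the change.

Going by these compounds, it remains open how a free hydrogen on this nitrogen, an acetyl group or a chain ending in a carboxylic acid would read in this assay. On these data alone, it is also open whether any group at this position can move the number beyond the scatter.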